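Isothiazolone acetamides against KAT2B: an amide substituent swap

The source may report more compounds than this note shows. Statements on the series, on what has been measured and on what is new or still open speak of the compounds shown alone.

Measured so far:
compound 1, `COCCNC(=O)Cn1sc2ccccc2c1=O`, 92%
compound 2, `CCNC(=O)OCCn1sc2nc(C)cc(C)c2c1=O`, 14%
compound 3, `CCOC(=O)Cn1sc2nc(C)cc(C)c2c1=O`, 97%

In an assay on isolated protein for inhibition of histone acetyltransferase KAT2B (Homo sapiens), read by fluorescence, with a stated time of 10 min, tested at 50 uM (a lower number here means less inhibition, a higher number more inhibition at the concentration tested (going by the name of the read-out)), compound 1 gives 92%, the second highest of the three numbers. The nearest neighbour is compound 3, whose value lies within the usual scatter of that of compound 1, so no order between these two can be claimed. Compound 2 stands far lower, beyond the scatter, and its ethyl carbamate chain is the only departure here from a direct acetamide or acetate link to the core.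

Compound 4, `O=C(Cn1sc2ccccc2c1=O)Nc1nccs1`, differs from compound 1 in one place: 1,3-thiazol-2-yl in place of 2-methoxyethyl on an amide-type nitrogen. The acetamide link to the shared core is kept, which is the feature compound 1 and compound 3 have in common and compound 2 lacks. No change at this amide nitrogen has yet been measured, so the step is guessed from the two high values of compound 1 and compound 3. The step of a number 2 percentage points lower from compound 1 to compound 4 (within the scatter) is expected to be small, well within the scatter, with no real direction. Compound 4 is estimated at 90%, in a range from 70% to 100%.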

Compound 4, a percentage reported as inhibition, at one concentration (the size of the read-out at that concentration, not a potency): 97%
Compound 4: middle estimate off by 7 percentage points, on the low side; the measured number falls inside the stated range.
By their numbers in this assay, from the lowest: compound 2; then compounds 1, 3 and 4 (each within the scatter of the next).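

In this assay, among the compounds shown here, this is the first measured change on the amide nitrogen of the acetamide link, and 1,3-thiazol-2-yl in place of 2-methoxyethyl amounts to a number 5 percentage points higher from compound 1 to compound 4 (within the scatter). This position therefore carries either an open chain with an ether oxygen or a five-membered aromatic ring with no difference that can be told from the scatter. The measurements shown offer no explanation for how alike the two groups read.

As far as these compounds go, whether a chain ending in an amine, a carboxylic acid or a longer alkyl chain on this amide nitrogen would read the same remains open. Also open, from the compounds shown here alone, is whether compound 1 and compound 4 would separate at a lower concentration, since a reading at one concentration is not a potency.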